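Ethyl in place of bromo: expecting compound 4

The source may hold more compounds than are shown below. What is called first, only, known or untested is meant among the compounds shown, and "the series" means these compounds.

Compound 2, `O=C(/C=C/c1ccc2c(c1)B(O)OC2)c1ccc(Br)cc1`, was tested in an ADME assay on L929 cells (Mus musculus) for cytotoxicity, read by resazurin assay, with a stated time of 72 h; on this read-out lower numbers stand for stronger inhibition and higher numbers for weaker inhibition. In this assay compound 2 gives only a limit, > 10 ug/mL, and not a number. Its two neighbours share that picture. Compound 1, `O=C(/C=C/c1ccc2c(c1)B(O)OC2)c1ccc(O)cc1`, gives a limit of > 10 ug/mL in this assay. Compound 3, `O=C(/C=C/c1ccc2c(c1)B(O)OC2)c1cccc(F)c1`, gives a limit of > 10 ug/mL in this assay. The steps among them are unreadable, a step that the two limits leave unreadable from compound 1 to compound 2, a step that the two limits leave unreadable from compound 1 to compound 3 and a step that the two limits leave unreadable from compound 2 to compound 3, because of the limit of > 10 ug/mL in this assay, at which 3 of the 3 values shown sit. Compound 4, `CCc1ccc(C(=O)/C=C/c2ccc3c(c2)B(O)OC3)cc1`, differs from compound 2 by ethyl in place of bromo on an aromatic carbon. Among the measured compounds shown here, none of the measured steps shows a readable direction, so no change beyond the scatter is expected. Compound 4 is expected to sit at the limit as well, estimated at 20 ug/mL with a range from 10 ug/mL to 50 ug/mL. The step this expectation implies is a step that the limit leaves unreadable from compound 2 to compound 4.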

Compound 4, half-maximal inhibitory concentration: > 10 ug/mL
Compound 4: a limit, no number (the forecaster's own chance of this, stated with the estimate: 80%); the middle value is on the limit's open side.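

Compound 4 also gives only a limit, so no step from compound 1 or compound 2 to compound 4 can be read: the limit of > 10 ug/mL in this assay, at which 4 of the 4 values shown sit.

The compounds shown leave open whether bromo, hydroxy and ethyl differ at all in this assay.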